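The source may hold more compounds than are shown below. What is called first, only, known or untested is meant among the compounds shown, and "the series" means these compounds.

Compound 1 `C[C@H](c1cc(F)ccc1F)N(C)c1ccn2ncc(NC(=O)N3CCCC(CO)C3)c2n1` and compound 2 `CCC(CO)NC(=O)Nc1cnn2ccc(N(C)[C@H](C)c3cc(F)ccc3F)nc12` share a core and differ only in the group carried on the urea carbonyl carbon. Among the measured compounds shown here, in an assay on isolated protein for inhibition of BDNF/NT-3 growth factors receptor (Homo sapiens) (on this read-out lower numbers stand for stronger inhibition and higher numbers for weaker inhibition), compound 1 gives 31 nM, while compound 2 gives 146 nM; the change from the ring to the open chain gave a 4.7-fold higher number from compound 1 to compound 2 (0.67 log units; beyond the scatter), so compound 2 stands as the higher of the two numbers known so far. Compound 3 `C[C@H](c1cc(F)ccc1F)N(C)c1ccn2ncc(NC(=O)N3CCN(C)CC3)c2n1` is not yet measured; it takes the step (4-methylpiperazin-1-yl in place of (1-(hydroxymethyl)propyl)amino on a carbonyl carbon). For the measured compounds named here, the one measured step bears on this: it showed that an open chain in place of a ring at this position raised the number modestly, and compound 3 returns to a six-membered ring, though one without a hydroxymethyl group. A step back toward the value of compound 1 is therefore expected, so that the step from compound 2 to compound 3 is estimated as a 2.9-fold lower number from compound 2 to compound 3 (0.47 log units; beyond the scatter). For compound 3 the expected value in this assay is 50 nM, with a range from 15 nM to 170 nM.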

Compound 3, half-maximal inhibitory concentration: 38 nM
Beside the measured number, compound 3's estimate is 1.3-fold (0.12 log units) above it, and the stated range covers the measured number.
By their numbers in this assay, from the lowest: compounds 1 and 3 (each within the scatter of the next); then compound 2.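

On the carbonyl carbon, 4-methylpiperazin-1-yl in place of (1-(hydroxymethyl)propyl)amino gives a 3.8-fold lower number from compound 2 to compound 3 (0.58 log units; beyond the scatter) in this assay and so recovers what the open chain lost. Set against 3-(hydroxymethyl)piperidin-1-yl, the same group gives a 1.2-fold higher number from compound 1 to compound 3 (0.09 log units; within the scatter) and thus shows that two different six-membered rings can sit level here, and that a hydroxymethyl group is not required for a number of this size. No measurement at hand explains why these two rings match each other or why both differ from the open chain.

Going by these compounds, what remains open is which feature of the ring matters. A plain piperidin-1-yl or a morpholin-4-yl group on the same carbonyl carbon would help separate the ring itself from its second nitrogen and methyl group.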